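A few compounds are considered here, and "the series" means these few. Any claim that something is new, unique, unknown or untested is made for them only; others in the source may bear on it.

Working notes on the series. Of the compounds shown here, three sharing one core have been measured in a functional assay on PC-3 cells (Homo sapiens) for inhibition, read by MTT assay, with a stated time of 72 h; a higher number here means a weaker inhibitor, a lower number a stronger inhibitor. Compound 1 `C=CC(=O)Nc1cccc(NC(=O)CSc2nc(Nc3cccc(F)c3)c3ccccc3n2)c1` gives 5370 nM. Compound 2 `C=CC(=O)Nc1cccc(NC(=O)CSc2nc(Nc3cccc(C)c3)c3ccccc3n2)c1` gives 29200 nM. Compound 3 `C=CC(=O)Nc1cccc(NC(=O)CSc2nc(Nc3cccc(OC)c3)c3ccccc3n2)c1` gives 34900 nM, the highest of the three numbers; against compound 2 the gap is a 1.2-fold higher number from compound 2 to compound 3 (0.08 log units; within the scatter), so the two cannot be ordered, while against compound 1 the gap is a 6.5-fold higher number from compound 1 to compound 3 (0.81 log units; beyond the scatter).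

Compound 4 `C=CC(=O)Nc1cccc(NC(=O)CSc2nc(Nc3ccc(F)c(Cl)c3)c3ccccc3n2)c1` is not yet measured. Its change from compound 3 is 3-chloro-4-fluorophenyl in place of 3-methoxyphenyl on a nitrogen on an aromatic ring. Within the data shown here, the step that bears on this is the one from compound 1 to compound 3, which was a 6.5-fold higher number from compound 1 to compound 3 (0.81 log units; beyond the scatter) on moving from fluoro to methoxy; the step from compound 1 to compound 2, a 5.4-fold higher number from compound 1 to compound 2 (0.74 log units; beyond the scatter), points the same way for methyl. Among the measured compounds shown here, compound 4 returns a halogen-bearing ring, so a step back down is expected, roughly undoing the earlier loss, though the added chloro has no precedent here. Compound 4 is therefore expected to give 6000 nM in this assay, within 2000 nM to 20000 nM, an expected step of a 5.8-fold lower number from compound 3 to compound 4 (0.76 log units; beyond the scatter).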

Compound 4, half-maximal inhibitory concentration: > 50000 nM
Compound 4: a limit, no number; the forecaster's own chance of this, stated with the estimate: 5%; middle value at least 8.3-fold (0.92 log units) from the limit.
By their numbers in this assay, from the lowest: compound 1; then compounds 2 and 3 (each within the scatter of the next). At a limit, above all of these: compound 4.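

Compound 4's reading in this assay is a limit and not a number: the limit of > 50000 nM in this assay, at which 1 of the 4 values shown sits. The step that lies beyond the scatter is an at least 9.3-fold higher number from compound 1 to compound 4 (0.96 log units; beyond the scatter), so at this position a fluoro-bearing ring does not by itself keep the low number of compound 1, and the earlier link between halogen and the lower number does not hold for the 3-chloro-4-fluorophenyl group of compound 4. The other two steps, an at least 1.4-fold higher number from compound 3 to compound 4 (0.15 log units; that floor lies within the scatter) and an at least 1.7-fold higher number from compound 2 to compound 4 (0.23 log units; that floor lies within the scatter), cannot be read further, as their floors lie within the scatter.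

Open is whether the chloro, the second ring substituent or the pair accounts for the rise, since no compound shown isolates them. Also open, going by these compounds, is how this assay would read a nitrile or an amine on this ring.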